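The compounds below may be only part of what the source reports. "The series", "measured", "known", "first", "only" and "open" are said of these compounds alone.

The series shares one core and varies only the aryl group on the saturated ring carbon. Compound 1 `O=C1NC(=O)/C(=C\c2ccc(OCC(=O)N3N=C(c4ccc(F)cc4)CC3c3ccccc3)cc2)S1` gives 4200 nM in an assay on cells for inhibition of histone deacetylase 4 (Homo sapiens), read by fluorescence, with a stated time of 30 min; on this read-out lower numbers stand for stronger inhibition and higher numbers for weaker inhibition. Compound 2 `O=C1NC(=O)/C(=C\c2ccc(OCC(=O)N3N=C(c4ccc(F)cc4)CC3c3ccccc3Cl)cc2)S1` gives 1100 nM in this assay, and compound 3 `O=C1NC(=O)/C(=C\c2ccc(OCC(=O)N3N=C(c4ccc(F)cc4)CC3c3ccc(C(F)(F)F)cc3)cc2)S1` gives 1300 nM. On these three numbers compound 3 stands second highest: its nearest neighbour is compound 2, within the scatter, and its furthest is compound 1, beyond it.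

Compound 4 `O=C1NC(=O)/C(=C\c2ccc(OCC(=O)N3N=C(c4ccc(F)cc4)CC3c3ccc(F)cc3F)cc2)S1` differs from compound 3 by 2,4-difluorophenyl in place of 4-(trifluoromethyl)phenyl on a saturated ring carbon. Going by the values given here, two measured steps bear on this change. The step of a 3.2-fold lower number from compound 1 to compound 3 (0.51 log units; beyond the scatter) and the step of a 3.8-fold lower number from compound 1 to compound 2 (0.58 log units; beyond the scatter) both show that a substituent on this phenyl ring lowers the number by a modest amount compared with the unsubstituted ring of compound 1, whereas the step of a 1.2-fold higher number from compound 2 to compound 3 (0.07 log units; within the scatter) shows that the choice between chloro and trifluoromethyl, and between the two positions, makes no difference beyond the scatter. Compound 4 again carries substituents on this ring, so a number close to compound 3 is expected, with at most a small downward lean; the step of a 1.3-fold lower number from compound 3 to compound 4 (0.11 log units; within the scatter) is therefore expected to fall within the scatter. For compound 4 the estimate is 1000 nM, with a range from 400 nM to 2500 nM.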

Compound 4, half-maximal inhibitory concentration: 1600 nM
Compound 4: the middle estimate sits 1.6-fold (0.20 log units) below what was measured, and the stated range covers the measured number.
By their numbers in this assay, from the lowest: compounds 2, 3 and 4 (each within the scatter of the next); then compound 1.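

The 2,4-difluorophenyl group behaves at this saturated ring carbon like the two substituted rings measured before it: in this assay there is a 1.2-fold higher number from compound 3 to compound 4 (0.09 log units; within the scatter) and a 1.5-fold higher number from compound 2 to compound 4 (0.16 log units; within the scatter), so these steps do not separate the three substituted rings, while a 2.6-fold lower number from compound 1 to compound 4 (0.42 log units; beyond the scatter) sets this ring apart from the unsubstituted phenyl as well. The new ring carries fluorine at both of the ring positions named separately in 2-chlorophenyl and 4-(trifluoromethyl)phenyl, yet having both positions filled gives no step beyond the scatter from either of those groups, so these data show no adding up of substituent effects on this ring. Nothing available on these compounds accounts for this outcome.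

The compounds shown leave open whether the same level holds for other substituents on this ring, such as an amine, a carboxylic acid or a methoxy group. They also leave open how the number responds to changes elsewhere, since all four compounds share the 4-fluorophenyl group and the rest of the core.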